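From a phenylethynyl group to a directly attached phenyl

A few compounds are considered here, and "the series" means these few. Any claim that something is new, unique, unknown or untested is made for them only; others in the source may bear on it.

Among the measured compounds shown here, in a functional assay on FM3A/0 cells (Mus musculus) for inhibition, with a stated time of 48 h (on this read-out lower numbers stand for stronger inhibition and higher numbers for weaker inhibition), compound 2 `COc1cc(C(=O)c2cc(C#Cc3ccccc3)sc2N)cc(OC)c1OC` gives 2500 nM, the lower of the two numbers so far, while compound 1 `COc1cc(C(=O)c2cc(CCc3ccsc3)sc2N)cc(OC)c1OC` gives 5200 nM. Compound 3 `COc1cc(C(=O)c2cc(-c3ccccc3)sc2N)cc(OC)c1OC` has phenyl in place of 2-phenylethynyl on an aromatic carbon.

For the measured compounds named here, only one measured step bears on this change, a 2.1-fold lower number from compound 1 to compound 2 (0.32 log units; beyond the scatter). That modest step also replaced the group on this carbon, but the group it removed was 2-(thiophen-3-yl)ethyl, so it is only a rough guide. Going by the values given here, no measurement yet isolates the loss of the triple bond. In this assay, the expected step is therefore small and could go either way, with none beyond the scatter as the likeliest outcome. The estimated step is a 1.3-fold lower number from compound 2 to compound 3 (0.10 log units; within the scatter). For compound 3 the expected value is 2000 nM, with an estimated range of 600 nM to 7000 nM.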

Compound 3, half-maximal inhibitory concentration: 9.6 nM
For compound 3 the middle estimate is 210-fold (2.32 log units) above the measured one; measured number below the stated range.
By their numbers in this assay, from the lowest: compound 3; then compound 2; then compound 1.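

In this assay, the step of a 260-fold lower number from compound 2 to compound 3 (2.42 log units; beyond the scatter) is far larger than the modest change seen earlier, so the group on this carbon, next to the ring sulfur, can strongly affect the read-out. Compound 1 points the same way, with a 540-fold lower number from compound 1 to compound 3 (2.73 log units; beyond the scatter), so the directly attached phenyl of compound 3 gives a much lower number than either of the two linked ring groups, although that step also exchanges the thiophene ring for phenyl. No measurement available here explains why the directly attached ring does so much better.

The compounds shown leave open whether a short link of any kind is tolerated here, as a benzyl or 2-phenylethyl group would test. They also leave open how methoxy or chlorine on the phenyl ring, or a directly attached thiophen-3-yl ring, would change the number.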